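A few compounds are considered here, and "the series" means these few. Any claim that something is new, unique, unknown or untested is made for them only; others in the source may bear on it.

Series notes on permeability.

Compound 1 `Cn1cc(C(=O)Nc2ccc(-c3ccccc3)c(C(F)(F)F)c2)c(=O)c2cnccc21`, compound 2 `Cn1cc(C(=O)Nc2ccc(-c3ccccn3)c(C(F)(F)F)c2)c(=O)c2ccccc21` and compound 3 `Cn1nc(C(=O)Nc2ccc(-c3ccccc3)c(C(F)(F)F)c2)c(=O)c2ccccc21` have been measured in an ADME assay on LLC-PK1 cells (Sus scrofa) for permeability; a lower number here means that the compound crosses the layer more slowly, a higher number that the compound crosses the layer faster. Compound 1 gives 5.7 10^-6 cm/s, compound 2 gives 11 10^-6 cm/s and compound 3 gives 2.3 10^-6 cm/s. Compound 2 stands highest of the three numbers; the number of compound 1 lies within the usual scatter of it, so no order between compound 1 and compound 2 is claimed, while the number of compound 3 lies beyond the scatter below it.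

Compound 4 `Cn1cc(C(=O)Nc2ccc(-c3ccccc3)c(C(F)(F)F)c2)c(=O)c2ccccc21` has not yet been measured in this assay. It differs from compound 2 in one place:
phenyl in place of pyridin-2-yl on an aromatic carbon
Within the data shown here, no step between two measured compounds matches this change. Compound 1 and compound 3 carry a phenyl at this place already, but each on a different core, so their values alone cannot fix the size of the step. For compound 4 in this assay a small step is expected, upward if anything and not clearly beyond the scatter, so that the estimated step of a 1.2-fold higher number from compound 2 to compound 4 (0.07 log units; within the scatter) is modest. Compound 4 is expected to give 13 10^-6 cm/s, with a range from 6.5 10^-6 cm/s to 26 10^-6 cm/s.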

Compound 4, apparent permeability in the LLC-PK1 assay: 1.2 10^-6 cm/s
Beside the measured number, compound 4's estimate is 11-fold (1.03 log units) above it; the measured number lies below the stated range.
By their numbers in the LLC-PK1 assay, from the lowest: compounds 4 and 3 (each within the scatter of the next); then compounds 1 and 2 (each within the scatter of the next).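

Among these compounds, in the LLC-PK1 assay, the exchange of pyridin-2-yl for phenyl on this aromatic carbon, ortho to a trifluoromethyl group, gives the first readable step at this place, a 9.2-fold lower number from compound 2 to compound 4 (0.96 log units; beyond the scatter), and shows that the position is not indifferent to this change on the shared core. In a physicochemical assay for solubility, in phosphate buffer, at pH 7.4 (on this read-out higher numbers stand for higher solubility and lower numbers for lower solubility), compound 2 gives < 1 ug/mL, which is a limit of the assay. In the physicochemical assay compound 4 gives < 1 ug/mL, again a limit of the assay.

From the compounds shown here alone, the step between these two compounds in the physicochemical assay cannot be read because neither value is a number: the limit of < 1 ug/mL in the physicochemical assay, at which 2 of the 2 values shown sit. It remains open whether the step in the LLC-PK1 assay carries over to the cores of compound 1 and compound 3, and how an amine or a carboxylic acid on the ring at this place would read in either assay.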